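Chloro in place of methyl: notes on compound 3

A few compounds are considered here, and "the series" means these few. Any claim that something is new, unique, unknown or untested is made for them only; others in the source may bear on it.

Measured so far in a physicochemical assay for lipophilicity; on this read-out lower numbers stand for lower lipophilicity and higher numbers for higher lipophilicity
- compound 1 `CC(C)(C)c1cc([N+](=O)[O-])c2ccccc2[n+]1[O-]` gives 1.07
- compound 2 `Cc1ccc2c(c1)c([N+](=O)[O-])cc[n+]2[O-]` gives 1.24

Compound 2 stands within the scatter of compound 1 in this assay, so these two values set no order between them. Among the compounds with values here, no two measured compounds differ in only one place, which leaves the series without a measured step to serve as a guide.

Compound 3 `O=[N+]([O-])c1cc[n+]([O-])c2ccc(Cl)cc12` differs from compound 2 by one change, chloro in place of methyl on an aromatic carbon. No step beyond the scatter is expected in this assay, with a small rise the likelier direction. The estimated step is a number 0.11 log units higher from compound 2 to compound 3 (within the scatter), which would remain within the scatter. Compound 3 is expected at 1.35, with an estimated range from 0.95 to 1.75.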

Compound 3, partition coefficient: 1.4
Compound 3: middle estimate off by 0.05 log units, on the low side, within the range that was stated.
By their numbers in this assay, from the lowest: compounds 1, 2 and 3 (each within the scatter of the next, the first and the last beyond it).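

Chloro in place of methyl on an aromatic carbon gives the series its first measured step, and in this assay that step is a number 0.16 log units higher from compound 2 to compound 3 (within the scatter). At this position, meta to a fused ring and para to a fused ring, the exchange therefore leaves the read-out within the scatter, something that compound 1 and compound 2, which differ in more than one place, could not show. Nothing on hand explains this outcome or ties it to a property of either group.

On these data alone, whether other groups at this position, such as an amine, a carboxylic acid or a longer chain, would also stay within the scatter of compound 2 remains open. Also open, as far as these compounds go, is whether chloro in place of methyl on another aromatic carbon of the shared core would give a step of similar size.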